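A few compounds are considered here, and "the series" means these few. Any claim that something is new, unique, unknown or untested is made for them only; others in the source may bear on it.

This account follows one change within a small set of related compounds assessed in an ADME assay on MDCK cells (Canis lupus familiaris) for cytotoxicity, read by microscopy, with a stated time of 72 h; a lower number here means that less compound is tolerated, a higher number that more compound is tolerated. Compound 1 `COC(=O)C[C@H](NC(=O)OC(C)(C)C)C(=O)N(Cc1ccc(F)cc1)C(C)(C)C(=O)NCc1ccccc1` gives 20000 nM in this assay. Compound 2 `COC(=O)C[C@H](NC(=O)OC(C)(C)C)C(=O)N(Cc1ccc(F)cc1)C1(C(=O)NCc2ccccc2)CCNCC1` gives 100000 nM in this assay, and compound 3 `CCC(C)N(C(=O)[C@H](CC(=O)OC)NC(=O)OC(C)(C)C)C1(C(=O)NCc2ccccc2)CCN(Cc2ccccc2)CC1` gives 84000 nM in this assay. Among these three numbers compound 3 stands second highest. Its nearest neighbour is compound 2, whose number lies within the usual scatter of that of compound 3, so no order between the two can be claimed. Compound 1 lies furthest away, with a number beyond the scatter and lower than that of compound 3.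

The step considered here leads from compound 3 to compound 4 `COC(=O)C[C@H](NC(=O)OC(C)(C)C)C(=O)N(Cc1cccc(F)c1)C1(C(=O)NCc2ccccc2)CCN(Cc2ccccc2)CC1`, which has not yet been measured in this assay. The change is 3-fluorobenzyl in place of sec-butyl on an amide-type nitrogen. Among the compounds with values here, no step between two measured compounds carries this same change, so the expectation rests only on the spread of the three known numbers, two of which lie within the scatter of each other. The step is expected to be small, a 1.2-fold lower number from compound 3 to compound 4 (0.08 log units; within the scatter), with no direction beyond the scatter. Compound 4 is therefore estimated to give 70000 nM in this assay, with a range from 30000 nM to 150000 nM.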

Compound 4, minimum cytotoxic concentration: 47000 nM
The estimate for compound 4 lay 1.5-fold (0.17 log units) above the measured number; measured number inside the range.
By their numbers in this assay, from the lowest: compound 1; then compounds 4, 3 and 2 (each within the scatter of the next, the first and the last beyond it).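

Within the data shown here, at this amide-type nitrogen, whose other neighbours are a carbonyl carbon and a saturated ring carbon, exchanging sec-butyl for 3-fluorobenzyl gives in this assay a 1.8-fold lower number from compound 3 to compound 4 (0.25 log units; within the scatter) and so provides the first reading of a change at this position. The minimum cytotoxic concentration therefore cannot be told apart for the two compounds, even though the entering group brings a six-membered aromatic ring of carbon only and a fluorine atom that sec-butyl lacks, so this one pair shows that an open-chain group and an aromatic one can be exchanged here without a difference beyond the scatter. No independent measurement bears on the reason for this outcome.

Among these compounds, the single pair leaves open whether the same holds for other groups on this nitrogen, such as an unsubstituted benzyl or a chain ending in an amine or a carboxylic acid. Among the compounds shown here, it also cannot say whether the fluorine contributes anything of its own, or whether the result would carry over to a core other than the one shared by compound 3 and compound 4.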